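Series notes: azido replaced by a chlorophenoxyethyl chain

This account rests on a few compounds, and the source may have more. Where it says the series, first, only, none or still open, it means among the compounds named here.

Measured so far:
compound 1 `[N-]=[N+]=NCCCN1CCCC(COC(=O)c2ccccc2-c2ccccc2)C1` — 4270 nM
compound 2 `COc1ccc(OCCCCCN2CCCC(COC(=O)c3coc4ccccc4c3=O)C2)cc1` — 10000 nM

In an in vitro functional assay on HEK ts201 cells for antagonist activity at Neuronal acetylcholine receptor; alpha4/beta2 (Homo sapiens), read by fluorescence and calcium flux (a higher number here means a weaker inhibitor, a lower number a stronger inhibitor), compound 1 gives 4270 nM, the lowest of the two numbers. Compound 2 gives 10000 nM in this assay, and the gap between the two values lies beyond the scatter. Compound 1 and compound 2 differ in more than one place, so nothing beyond their two values is stated about that pair.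

Compound 3 `O=C(OCC1CCCN(CCCCCOc2ccc(Cl)cc2)C1)c1ccccc1-c1ccccc1` differs from compound 1 in one place: 2-(4-chlorophenoxy)ethyl in place of azido on a saturated chain carbon, three bonds along the chain from an amine nitrogen in a ring. Going by the values given here, no measured pair carries this change, so its size is not known from the numbers at hand. Among the compounds with values here, the only other compound that bears a phenoxy-terminated chain on the amine nitrogen in the ring, compound 2, gives 10000 nM, but its ester part also differs, so it is a weak guide. The step from compound 1 to compound 3 is therefore estimated as a 1.5-fold higher number from compound 1 to compound 3 (0.18 log units; within the scatter), a weakening that may not clear the scatter. Compound 3 is expected to give about 6500 nM in this assay, within 2000 nM to 20000 nM.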

Compound 3, half-maximal inhibitory concentration: 14500 nM
The estimate for compound 3 lay 2.2-fold (0.35 log units) below the measured number; measured number inside the range.
By their numbers in this assay, from the lowest: compound 1; then compounds 2 and 3 (each within the scatter of the next).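

In this assay, going by these compounds alone, placing 2-(4-chlorophenoxy)ethyl in place of azido on a saturated chain carbon, three bonds along the chain from an amine nitrogen in a ring, gives a 3.4-fold higher number from compound 1 to compound 3 (0.53 log units; beyond the scatter), which is the first measured size of a change at this position. The position is therefore not indifferent to what it carries: with the rest of compound 1 unchanged, the entering group of 10 heavy atoms, with its six-membered aromatic ring, gives a weaker inhibitor than the azido of 3 heavy atoms, though the step is modest and compound 3 still gives a numerical reading. No supporting measurement bears on the origin of this step.

Within the data shown here, the single step changes the size of the group, the aromatic ring and the chlorine together, so their separate shares in the weakening remain open. From the compounds shown here alone, whether any group at this position gives a lower number than azido also remains open, and a plain phenoxy, a primary amine or a hydroxyl in place of azido would each test a different part of that question.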